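Spiro compounds tested for paw-edema inhibition in rats

A few compounds are considered here, and "the series" means these few. Any claim that something is new, unique, unknown or untested is made for them only; others in the source may bear on it.

Compound 1 `CN1C[C@@H](c2ccccc2)[C@@]2(Cc3ccccc3C2=O)[C@@]12C(=O)Nc1ccccc12` was tested in a functional assay on the whole organism (strain Wister albino) for inhibition, with Rattus norvegicus as the target, read by paw edema, with stated times of 1 h and 4 h, at a dose of 50 mg/kg by the intraperitoneal route (on this read-out higher numbers stand for more inhibition at the one dose given (going by the name of the read-out) and lower numbers for less inhibition), where compound 1 gives 39.3%. That is the higher of the two measured numbers: compound 2 `CN1C(=O)[C@@]2(c3ccccc31)N(C)C[C@@H](c1ccc(Cl)cc1)[C@@]21Cc2ccccc2C1=O` gives 8.5%, a gap beyond the usual scatter, although compound 2 differs from compound 1 in more than one place. Compound 3 `COc1ccc([C@@H]2CN(C)[C@]3(C(=O)Nc4ccccc43)[C@]23Cc2ccccc2C3=O)cc1` is not yet measured; it differs from compound 1 by methoxy in place of hydrogen on an aromatic carbon. Among the compounds with values here, no measured pair isolates this change, so only a small downward step or none beyond the scatter is expected, a number 7.3 percentage points lower from compound 1 to compound 3 (within the scatter). Compound 3 is therefore estimated at 32%, within 15% to 48%.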

Compound 3, a percentage reported as inhibition, in the whole organism at one dose (the size of the read-out at that dose, not a potency): 21.8%
Beside the measured number, compound 3's estimate is 10.2 percentage points above it, and the stated range covers the measured number.
By their numbers in this assay, from the lowest: compound 2; then compound 3; then compound 1.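

In this assay, the change from phenyl to 4-methoxyphenyl gives a number 17.5 percentage points lower from compound 1 to compound 3 (beyond the scatter). Within the data shown here, this is the first pair in the set that differs in one place only, so the loss of inhibition at this dose can be tied to this single change on the aromatic ring. No measurement here bears on why the number falls.

Going by these compounds, it remains open whether the drop is particular to methoxy or would also follow other groups at this place, such as an amine or a carboxylic acid. One pair also cannot show whether the same change would lower inhibition on another compound.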